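A few compounds are considered here, and "the series" means these few. Any claim that something is new, unique, unknown or untested is made for them only; others in the source may bear on it.

Compound 1 `CNC(=O)c1cc(C(=O)NC2CC2)cn(CC2CCCOC2)c1=O` carries the lowest of the three numbers measured in a physicochemical assay for lipophilicity, at pH 7.4 (a lower number here means a more polar compound, a higher number a more lipophilic compound), giving 2. Compound 2 `CNC(=O)c1cccn(Cc2ccccc2)c1=O` gives 3 in this assay, and compound 3 `CNC(=O)c1cc(C(=O)NCCC(C)C)cn(Cc2ccccc2)c1=O` gives 4.8. Going by the values given here, the only single-point step among the measured compounds is a number 1.80 log units higher from compound 2 to compound 3 (beyond the scatter), which concerns a carbamoyl substituent on the core rather than the group on the ring nitrogen. Compound 4 `CNC(=O)c1cc(C(=O)NC2CC2)cn(Cc2cccc3cn[nH]c23)c1=O` differs from compound 1 by 1H-indazol-7-yl in place of oxan-3-yl on a saturated chain carbon bound to an aromatic nitrogen. Among the compounds with values here, no measured step covers this change; compound 2 and compound 1 differ in two places, so their values show only that an aromatic group on that chain carbon accompanies a higher number. A modest upward step is therefore expected: a number 0.50 log units higher from compound 1 to compound 4 (beyond the scatter). Compound 4 is estimated at 2.5, within 1.9 to 3.1.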

Compound 4, distribution coefficient: 2.2
For compound 4 the middle estimate is 0.30 log units above the measured one; the measured number falls inside the stated range.
By their numbers in this assay, from the lowest: compounds 1 and 4 (each within the scatter of the next); then compound 2; then compound 3.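

Going by these compounds alone, at the saturated chain carbon bound to an aromatic nitrogen, the only step read in this assay is a number 0.20 log units higher from compound 1 to compound 4 (within the scatter). Here, 1H-indazol-7-yl, with 9 heavy atoms and 1 hydrogen-bond donor, cannot be told apart from oxan-3-yl, with 6 heavy atoms and 0 hydrogen-bond donors. No evidence is at hand that accounts for this result.

Still open, from the compounds shown here alone, is how an amine such as piperidin-4-yl, or a carboxylic acid, would read at this place. Also open, going by these compounds, is whether the 1H-indazol-7-yl result carries over to isopentylcarbamoyl on the core.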